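Swapping the hydrazone aryl group in a diaryl ether urea series

A few compounds are considered here, and "the series" means these few. Any claim that something is new, unique, unknown or untested is made for them only; others in the source may bear on it.

Compound 1 `CN(C)CCn1cnnc1-c1cc(Oc2ccc(NC(=O)N/N=C/c3c(O)ccc4ccccc34)cc2F)ccn1`: 670 nM
Compound 2 `CN(C)CCn1cnnc1-c1cc(Oc2ccc(NC(=O)N/N=C/c3ccc(Cl)cc3)cc2F)ccn1`: 530 nM

Both compounds were run in a functional assay on HT-29 cells (Homo sapiens) for cytotoxicity, read by MTT assay, with a stated time of 72 h; on this read-out lower numbers stand for stronger inhibition and higher numbers for weaker inhibition. In this assay compound 1 gives 670 nM, and compound 2 gives 530 nM. For the measured compounds named here, the one step between them, a 1.3-fold lower number from compound 1 to compound 2 (0.10 log units; within the scatter), shows that exchanging the aryl group on the hydrazone carbon left the read-out essentially unchanged; compound 2 and compound 1 lie within the scatter of each other, so neither can be set apart on these two numbers.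

Compound 3 `COc1cc(/C=N/NC(=O)Nc2ccc(Oc3ccnc(-c4nncn4CCN(C)C)c3)c(F)c2)ccc1O` carries the change (4-hydroxy-3-methoxyphenyl in place of 4-chlorophenyl on a carbon with a double bond to nitrogen). Going by the values given here, the only measured step that bears on this position is the one from compound 1 to compound 2, and it stayed within the scatter. On that basis compound 3 is expected to show no step beyond the scatter, a 1.3-fold higher number from compound 2 to compound 3 (0.12 log units; within the scatter). The estimate for compound 3 in this assay is therefore 700 nM, with a range from 250 nM to 2000 nM.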

Compound 3, half-maximal inhibitory concentration: 120 nM
Compound 3: the middle estimate sits 5.8-fold (0.77 log units) above what was measured; the measured number lies below the stated range.
By their numbers in this assay, from the lowest: compound 3; then compounds 2 and 1 (each within the scatter of the next).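

In this assay, the aryl group on a carbon with a double bond to nitrogen does matter: 4-hydroxy-3-methoxyphenyl in place of 4-chlorophenyl gives a 4.4-fold lower number from compound 2 to compound 3 (0.65 log units; beyond the scatter), and in place of 2-hydroxynaphthalen-1-yl it gives a 5.6-fold lower number from compound 1 to compound 3 (0.75 log units; beyond the scatter). The earlier step within the scatter therefore reflected that particular pair of groups, not a position indifferent to change, and a hydroxy group alone does not account for the lower number, since compound 1 also carries one and stays within the scatter of compound 2. Nothing available explains why 4-hydroxy-3-methoxyphenyl stands apart.

On these data alone, whether the hydroxy or the methoxy group alone, as in 4-hydroxyphenyl or 3-methoxyphenyl, would give the same number remains open. So does the outcome with an amine on the phenyl ring, as in 4-aminophenyl.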